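This account rests on a few compounds, and the source may have more. Where it says the series, first, only, none or still open, it means among the compounds named here.

Of the compounds shown here, two sharing one core have been measured in a functional assay, with a stated time of 10 min; a lower number here means a stronger inhibitor, a higher number a weaker inhibitor. Compound 1 `CSc1nc(-c2ccc(N(C)C)cc2)c(C#N)c(=O)n1C` gives 84 ug/mL. Compound 2 `Cn1c(NN)nc(-c2ccccc2F)c(C#N)c1=O` gives 49 ug/mL, the lowest of the two numbers, with compound 1 the nearest, at a gap that lies within the usual scatter of repeated measurements, so no order between the two can be claimed. Compound 3 `Cn1c(NN)nc(-c2ccccc2Cl)c(C#N)c1=O` has not yet been measured in this assay. It differs from compound 2 in one place: chloro in place of fluoro on an aromatic carbon. For the measured compounds named here, no step between two measured compounds covers this change, so nothing in the data fixes its size. Because compound 2 gives 49 ug/mL, compound 3 is expected to land near that number. The step of a 1.3-fold lower number from compound 2 to compound 3 (0.11 log units; within the scatter) is expected to be small, if anything toward a lower number, and not clearly beyond the scatter. Compound 3 is estimated at 38 ug/mL, between 12 ug/mL and 110 ug/mL.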

Compound 3, half-maximal inhibitory concentration: 46 ug/mL
Compound 3: the middle estimate sits 1.2-fold (0.08 log units) below what was measured, and the stated range covers the measured number.
By their numbers in this assay, from the lowest: compounds 3, 2 and 1 (each within the scatter of the next).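

For the compounds shown here, the only step so far between two measured compounds that differ in one place comes from this pair: in this assay, chloro in place of fluoro on an aromatic carbon, ortho to a large group, gives a 1.1-fold lower number from compound 2 to compound 3 (0.03 log units; within the scatter). At this position, then, the two halogens cannot be told apart in this read-out, and this exchange leaves the number where it was, as far as the scatter allows. Nothing measured here offers an explanation for this result.

Going by these compounds, both groups compared are single halogen atoms, so it remains open whether a methoxy group, an amine or a plain hydrogen at this same place would move the number beyond the scatter. On these data alone, it is also open whether the same exchange would stay this small with a different group on the rest of the shared core.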